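The source may hold more compounds than are shown below. What is called first, only, known or untested is meant among the compounds shown, and "the series" means these compounds.

Compound 1 `COc1cc(CNC(C)=O)ccc1F` and compound 2 `CCC(=O)NCc1ccc(F)c(OC)c1` share one core, and in an assay on isolated protein for agonist activity at melatonin receptor type 1C (Xenopus laevis), read by spectrophotometry (on this read-out lower numbers stand for an effect already at smaller amounts and higher numbers for an effect only at larger amounts of compound), compound 1 gives 2090 nM while compound 2 gives 2880 nM. The change between them, (methyl in place of hydrogen on a saturated chain carbon bound to a carbonyl carbon), made a 1.4-fold higher number from compound 1 to compound 2 (0.14 log units; within the scatter). Compound 3 `CCC(=O)NCCCc1cc(OC)ccc1F` rests on a different core; how its core differs from that of compound 1 is not broken down here. In this assay compound 3 gives 3.72 nM. Compound 4 `CCCC(=O)NCCCc1cc(OC)ccc1F` follows from compound 3 by methyl in place of hydrogen on a saturated chain carbon, two bonds along the chain from a carbonyl carbon. This is the same kind of change as that from compound 1 to compound 2, though not the same: there the entering methyl sat on a saturated chain carbon bound to a carbonyl carbon, here it sits on a saturated chain carbon two bonds along the chain from a carbonyl carbon. Because the step of a 1.4-fold higher number from compound 1 to compound 2 (0.14 log units; within the scatter) stayed within the scatter, the step from compound 3 to compound 4 is expected to be about a 1.2-fold higher number from compound 3 to compound 4 (0.08 log units; within the scatter). On that basis compound 4 is estimated at 4.5 nM, within a range from 1.5 nM to 15 nM.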

Compound 4, half-maximal effective concentration: 9.55 nM
Estimate against measurement, compound 4: 2.1-fold (0.33 log units) below; low and high end bracket the measured number.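

On the core of compound 3, the added methyl gives a 2.6-fold higher number from compound 3 to compound 4 (0.41 log units; beyond the scatter) in this assay. Set beside the related change on the core of compound 1, this step does not differ from it by more than repeated measurements would: the same change on two cores in this assay, a 1.4-fold higher number (0.14 log units; within the scatter) from compound 1 to compound 2 and a 2.6-fold higher number (0.41 log units; beyond the scatter) from compound 3 to compound 4, 1.9-fold (0.27 log units) apart, within the scatter of two such steps. The two cores therefore give no sign that this change behaves differently from one to the other, but two pairs cannot show that it would keep its size on a further core, and the methyl enters at a different place on the chain in each pair.

The compounds shown leave open how a longer chain than propylcarbonyl would read in this assay. They also leave open what an amine or a carboxylic acid at the end of that chain would do on either core.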